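Two Ring Changes on One Core and Their Lipophilicity

The source may report more compounds than this note shows. Statements on the series, on what has been measured and on what is new or still open speak of the compounds shown alone.

Compound 1 `Cn1nccc1-c1cc(C(F)(F)F)ccc1[C@H]1CCOc2cc(S(=O)(=O)Nc3nccs3)ccc21`: 2.2
Compound 2 `O=S(=O)(Nc1nccs1)c1ccc2c(c1)OCC[C@@H]2c1ccc(C(F)(F)F)cc1-c1ccc(F)cn1`: 3.5
Compound 3 `O=S(=O)(Nc1ccncn1)c1ccc2c(c1)OCC[C@@H]2c1ccc(C(F)(F)F)cc1-c1ccc(F)cn1`: 3

Of the compounds shown here, three have been measured in a physicochemical assay for lipophilicity; a higher number here means a more lipophilic compound, a lower number a more polar compound. Compound 2 stands highest. The change 1-methyl-1H-pyrazol-5-yl in place of 5-fluoropyridin-2-yl on an aromatic carbon gave a number 1.30 log units lower from compound 2 to compound 1 (beyond the scatter). The change (pyrimidin-4-yl in place of 1,3-thiazol-2-yl on a sulfonamide nitrogen), which is how the core of compound 3 differs from that of compound 2, gave a number 0.50 log units lower from compound 2 to compound 3 (beyond the scatter).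

Compound 4 `Cn1nccc1-c1cc(C(F)(F)F)ccc1[C@H]1CCOc2cc(S(=O)(=O)Nc3ccncn3)ccc21` is not yet measured. It differs from compound 3 by 1-methyl-1H-pyrazol-5-yl in place of 5-fluoropyridin-2-yl on an aromatic carbon, the same change that turned compound 2 into compound 1, made here on the core of compound 3. Because the earlier step was a number 1.30 log units lower from compound 2 to compound 1 (beyond the scatter), a step of about the same size is expected from compound 3, namely a number 1.30 log units lower from compound 3 to compound 4 (beyond the scatter). Starting from the value of compound 3, 3, compound 4 is estimated at 1.7, with a likely range from 1.3 to 2.1.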

Compound 4, distribution coefficient: 1.8
For compound 4 the middle estimate is 0.10 log units below the measured one; low and high end bracket the measured number.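

In this assay, putting 1-methyl-1H-pyrazol-5-yl in place of 5-fluoropyridin-2-yl on an aromatic carbon carried over to a second core: the step was large (a number 1.20 log units lower from compound 3 to compound 4 (beyond the scatter)), as it was on the first (a number 1.30 log units lower from compound 2 to compound 1 (beyond the scatter)). The change on the sulfonamide nitrogen, pyrimidin-4-yl in place of 1,3-thiazol-2-yl, also gave a modest step on both cores (a number 0.40 log units lower from compound 1 to compound 4 (beyond the scatter); a number 0.50 log units lower from compound 2 to compound 3 (beyond the scatter)). This agreement rests on these four compounds alone, says nothing about any other core, and nothing shown here accounts for it.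

The compounds shown leave open whether the steps would hold with an amine or a carboxylic acid in place of the aromatic ring on that carbon. As far as these compounds go, whether a longer chain on the sulfonamide nitrogen would follow the same pattern also stays open.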